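Furan swaps on the shared core: working notes

The source may report more compounds than this note shows. Statements on the series, on what has been measured and on what is new or still open speak of the compounds shown alone.

Measured so far:
compound 1 `COc1ccc(CNC(=O)/C(C#N)=C/c2ccc(C)o2)cc1`: 69000 nM
compound 2 `COc1ccc(CNC(=O)/C(C#N)=C/c2cc(Br)co2)cc1`: > 100000 nM

In a functional assay on SMA cells (Homo sapiens) for inhibition, read by MTT assay, with a stated time of 72 h (a higher number here means a weaker inhibitor of growth, a lower number a stronger inhibitor of growth), compound 1 gives 69000 nM. For compound 2 the value > 100000 nM is a limit of the assay, not a number. Compound 2 thus sits at the limit of > 100000 nM in this assay, at which 1 of the 2 values shown sits, so an at least 1.4-fold higher number from compound 1 to compound 2 (0.16 log units; that floor lies within the scatter) marks only a floor. Compound 3 `COc1ccc(CNC(=O)/C(C#N)=C/c2ccoc2)cc1` carries furan-3-yl in place of 4-bromofuran-2-yl on a double-bonded chain carbon bound to a double-bonded chain carbon. Among the compounds with values here, that single step is the only one bearing on this change, and it does not reach beyond the scatter, so no direction is read from it. The step from compound 2 to compound 3 is expected to be a number no higher from compound 2 to compound 3 (the limit leaves the size open). Compound 3 is therefore estimated at 100000 nM, within 40000 nM to 250000 nM.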

Compound 3, concentration for 50% growth inhibition: 7000 nM
For compound 3 the middle estimate is 14-fold (1.15 log units) above the measured one; the measured number lies below the stated range.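

At this place, on a double-bonded chain carbon bound to a double-bonded chain carbon, the choice of furan group now gives a clear direction in this assay: furan-3-yl gives an at least 14-fold lower number from compound 2 to compound 3 (1.15 log units; beyond the scatter) and a 9.9-fold lower number from compound 1 to compound 3 (0.99 log units; beyond the scatter). Compound 3 is the strongest of the three compounds shown. Compound 2 stands at a limit of the assay, so its step is only a floor: the limit of > 100000 nM in this assay, at which 1 of the 3 values shown sits.

Still open, going by these compounds, is whether the lower number follows the furan-3-yl attachment or the absence of the methyl and bromine groups. An unsubstituted furan-2-yl or a furan-3-yl bearing methyl would separate the two readings.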